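The compounds below may be only part of what the source reports. "The series", "measured", "known", "first", "only" and "open" are said of these compounds alone.

The measured compounds:
- compound 1, `CCOc1cc(C)c(C(N)=O)cn1`: > 10000 nM
- compound 2, `O=C1NCCc2ncccc21`: no result reported
- compound 3, `C[C@H]1Cc2cc(C(N)=O)cnc2N1`: > 10000 nM

In an assay on isolated protein for inhibition of Nicotinamide N-methyltransferase (Homo sapiens), read by luminescence, with a stated time of 20 min (on this read-out lower numbers stand for stronger inhibition and higher numbers for weaker inhibition), compound 1 gives only a limit of the assay, > 10000 nM, not a number. Compound 2 has no result in this assay. Compound 3 likewise reaches only a limit in this assay, > 10000 nM. For the measured compounds named here, compound 3 therefore stands at the edge of what was measured: two of the three entries sit at the limit of > 10000 nM in this assay, at which 2 of the 3 values shown sit, and the third carries no number at all, so no measured step between two compounds exists here to show how large a change can be.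

Compound 4, `C[C@@H]1Cc2cc(C(N)=O)cnc2N1`, is the still unmeasured partner of compound 3. The difference between them is the two compounds have the same atoms and bonds and differ only in configuration as drawn: 1 of 1 stereo elements differ; a stereocentre at a saturated ring carbon is drawn S in compound 3 and R in compound 4. With nothing else changed, no shift beyond the ordinary scatter is expected from compound 3 to compound 4, and the expected step is a number no higher from compound 3 to compound 4 (the limit leaves the size open). For compound 4 in this assay the estimate is 10000 nM, within a range of 3000 nM to 30000 nM, most likely again reported as a limit.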

Compound 4, half-maximal inhibitory concentration: 42 nM
Compound 4: the middle estimate sits 240-fold (2.38 log units) above what was measured, outside the stated range (below it).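

In this assay, changing only the drawn configuration at a saturated ring carbon gives an at least 230-fold lower number from compound 3 to compound 4 (2.37 log units; beyond the scatter). The value of compound 3, > 10000 nM, is a limit of the assay and not a number. The earlier compounds offered no step at all, whereas this pair shows that the R configuration at this single stereocentre can separate a compound at the limit from one with a measured value, with no other change involved: the fact that compounds 3 and 4 differ only in the configuration as drawn

The compounds shown leave open whether a larger group, such as an ethyl in place of the methyl at this stereocentre, would keep the value of compound 4. They also do not tell whether compound 4 would keep that value with a carboxylic acid in place of its amide.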